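Removing One Methoxy Group: Two Parallel Compound Pairs

The source may report more compounds than this note shows. Statements on the series, on what has been measured and on what is new or still open speak of the compounds shown alone.

Compound 1 `COc1cc(-c2cc(/C=C/C(=O)c3ccc(N)cc3)[nH]n2)cc(OC)c1OC`: 73200 nM
Compound 2 `COc1ccc(-c2cc(/C=C/C(=O)c3ccc(N)cc3)[nH]n2)cc1OC`: 95600 nM
Compound 3 `COc1cc(C(=O)/C=C/c2cc(-c3cc(OC)c(OC)c(OC)c3)n[nH]2)cc(OC)c1OC`: 64300 nM

In a functional assay on NCI-H23 cells (Homo sapiens) for inhibition, read by sulforhodamine B assay, with a stated time of 48 h (on this read-out lower numbers stand for higher toxicity in this test and higher numbers for lower toxicity in this test), compound 1 gives 73200 nM, compound 2 gives 95600 nM, and compound 3 gives 64300 nM. The three numbers lie within the scatter of one another. Compound 2 differs from compound 1 by hydrogen in place of methoxy on an aromatic carbon, and this gave a 1.3-fold higher number from compound 1 to compound 2 (0.12 log units; within the scatter). Compound 4 `COc1ccc(-c2cc(/C=C/C(=O)c3cc(OC)c(OC)c(OC)c3)[nH]n2)cc1OC` has not yet been measured in this assay; it differs from compound 3 by hydrogen in place of methoxy on an aromatic carbon, which is the same change as in the measured pair. How the core of compound 3 differs from that of compound 1 is not broken down here. Compound 4 is expected to show a 1.2-fold higher number from compound 3 to compound 4 (0.09 log units; within the scatter), resting on the measured pair, because a 1.3-fold higher number from compound 1 to compound 2 (0.12 log units; within the scatter) stayed within the scatter. Compound 4 is therefore estimated at 80000 nM, with a likely range from 40000 nM to 160000 nM.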

Compound 4, concentration lethal to 50% of the cells: > 100000 nM
Compound 4 gave a limit, no number; the forecaster's own chance of this, stated with the estimate: 15%; at least 1.2-fold (0.09 log units) between middle value and limit.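

In this assay, hydrogen in place of methoxy on an aromatic carbon gave an at least 1.5-fold higher number from compound 3 to compound 4 (0.19 log units; that floor lies within the scatter). Compound 4 stands at a limit of the assay and not at a number: the limit of > 100000 nM in this assay, at which 1 of the 4 values shown sits. The floor of this step and the earlier step both lie within the scatter, but the true size of the step on the second core remains unknown, so the data neither show that the change carries over unaltered nor show that the two cores respond differently: the same change on two cores in this assay, a 1.3-fold higher number (0.12 log units; within the scatter) from compound 1 to compound 2 and an at least 1.5-fold higher number (0.19 log units; that floor lies within the scatter) from compound 3 to compound 4; the limit leaves it open whether they differ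

The compounds shown leave open how an amine, a hydroxy group or a chlorine in place of that methoxy would read on either core. Among these compounds, with only two pairs, they also leave open how the same change would behave on a third core.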